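Sulfonyl in Place of Amide on a Fused Bicyclic Core

A few compounds are considered here, and "the series" means these few. Any claim that something is new, unique, unknown or untested is made for them only; others in the source may bear on it.

Going by the values given here, compound 3 `COC1CC(C(=O)N2CCc3nc(C#Cc4ccccc4)sc3C2)C1` is the only compound of this set with a numbered result: in an assay on HEK293 cells for positive allosteric modulation of metabotropic glutamate receptor 5 (Homo sapiens), read by FLIPR, with a stated time of 1 h (a higher number here means that more compound is needed for the effect, a lower number that less compound is needed), compound 3 gives 640 nM. Compound 1 `CCN1CCc2nc(C#Cc3ccccc3)sc2C1` reaches only a limit, > 10000 nM. Compound 2 `CCC(=O)N1CCc2nc(C#Cc3ccccc3)sc2C1` likewise stops at a limit, > 10000 nM. Both sit at the limit of > 10000 nM in this assay, at which 2 of the 3 values shown sit. Compound 4 `O=S(=O)(C1CC1)N1CCc2nc(C#Cc3ccccc3)sc2C1` carries cyclopropylsulfonyl in place of (3-methoxycyclobutyl)carbonyl on an amine nitrogen in a ring. The step from compound 1 to compound 2 is a step that the two limits leave unreadable from compound 1 to compound 2, whereas an at least 15-fold lower number from compound 1 to compound 3 (1.19 log units; beyond the scatter) and an at least 15-fold lower number from compound 2 to compound 3 (1.19 log units; beyond the scatter) are both large. The change to compound 4 removes the 3-methoxycyclobutyl that set compound 3 apart from compound 2, so a move back toward a higher number, a 4.7-fold higher number from compound 3 to compound 4 (0.67 log units; beyond the scatter), is expected. Compound 4 is therefore estimated at 3000 nM, within 800 nM to 12000 nM.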

Compound 4, half-maximal effective concentration: > 10000 nM
Compound 4: no number, only a limit; the forecaster's own chance of this, stated with the estimate: 40%; at least 3.3-fold (0.52 log units) between middle value and limit.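

In this assay, cyclopropylsulfonyl on the amine nitrogen does not keep what (3-methoxycyclobutyl)carbonyl gave at this position: the change brings an at least 15-fold higher number from compound 3 to compound 4 (1.19 log units; beyond the scatter). Going by these compounds alone, compound 4 gives only a limit, > 10000 nM, which leaves compound 3 as the only compound with a number: the limit of > 10000 nM in this assay, at which 3 of the 4 values shown sit. The steps to compound 4 from compound 1 and from compound 2 cannot be read, since both ends are limits.

The compounds shown leave open whether the loss follows the sulfonyl or the smaller ring. A (3-methoxycyclobutyl)sulfonyl or a cyclopropylcarbonyl on the same nitrogen would separate the two.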